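This account rests on a few compounds, and the source may have more. Where it says the series, first, only, none or still open, it means among the compounds named here.

Working notes on the series.

The shared core with the amide chain and the imidazole terminus is kept throughout; the variation sits on the aromatic nitrogen. In an assay on isolated protein for activation of Insulin-degrading enzyme (Homo sapiens), read by fluorescence, with stated times of 10 min and 20 min (on this read-out lower numbers stand for an effect already at smaller amounts and higher numbers for an effect only at larger amounts of compound), compound 2 `O=C(CCCc1cn(C(=O)c2cccs2)c2ccccc12)NCCCn1ccnc1` gives 21400 nM, and compound 3 `O=C(CCCc1cn(S(=O)(=O)c2ccccc2F)c2ccccc12)NCCCn1ccnc1` gives 7940 nM. Among the measured compounds shown here, the only single step among measured compounds, a 2.7-fold lower number from compound 2 to compound 3 (0.43 log units; beyond the scatter), is modest. Compound 1 `O=C(CCCc1cn(S(=O)(=O)c2cccs2)c2ccccc12)NCCCn1ccnc1` carries a thiophen-2-yl group on the sulfonyl sulfur and, by the several entries of compound 1 in this assay, 5500 nM; 5010 nM (2 entries), gives 5500 nM; 5010 nM (2 entries); these entries and the value of compound 3 lie within the scatter of one another. On the numbers available, compound 3 stands lowest of the two single numbers, with compound 2 the nearest.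

Compound 4 `O=C(CCCc1cn(S(=O)(=O)c2ccsc2)c2ccccc12)NCCCn1ccnc1` differs from compound 3 by thiophen-3-yl in place of 2-fluorophenyl on a sulfonyl sulfur. For the measured compounds named here, no measured step swaps an aryl for a thiophenyl on the sulfonyl sulfur; the closest bearing comes from compound 1, whose thiophene on the sulfonyl sulfur and value 5500 nM; 5010 nM (2 entries) sit within the scatter of compound 3. From this, no step beyond the scatter is expected in this assay in either direction, with the expected step of a 1.3-fold lower number from compound 3 to compound 4 (0.12 log units; within the scatter). For compound 4 the estimate is 6000 nM, expected within 3000 nM to 12000 nM.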

Compound 4, half-maximal effective concentration: 13800 nM
Beside the measured number, compound 4's estimate is 2.3-fold (0.36 log units) below it, and the stated range ends below it.
By their numbers in this assay, from the lowest: compounds 3, 4 and 2 (each within the scatter of the next, the first and the last beyond it).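

In this assay, the step to the sulfonyl thiophene gives a 1.7-fold higher number from compound 3 to compound 4 (0.24 log units; within the scatter), so on a sulfonyl sulfur the exchange of the six-membered aromatic ring of carbon only for a five-membered aromatic ring with 1 hetero atom cannot be told apart from the scatter. The second new step, a 1.6-fold lower number from compound 2 to compound 4 (0.19 log units; within the scatter), shows that a sulfonyl compound need not separate from the carbonyl compound, a distinction that the earlier step, a 2.7-fold lower number from compound 2 to compound 3 (0.43 log units; beyond the scatter), alone had suggested; the sulfonyl-for-carbonyl reading therefore holds for compound 3 and not for compound 4. For the two thiophene attachments on the sulfonyl sulfur, compound 4 gives 13800 nM, and the comparison on the thiophen-2-yl side is: the several entries of compound 1 in this assay, 5500 nM; 5010 nM (2 entries)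

What the compounds shown leave open is whether the fluorine of compound 3 contributes anything apart from its ring, which a plain phenyl on the sulfonyl sulfur would address. Equally open, from the compounds shown here alone, is whether an aminophenyl or carboxyphenyl group at this place, or a longer chain between the amide and the imidazole, would give a step beyond the scatter in either direction.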